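The source may hold more compounds than are shown below. What is called first, only, known or untested is meant among the compounds shown, and "the series" means these compounds.

Three compounds share one core and were tested in a functional assay on HCT-116 cells (Homo sapiens) for antiproliferative activity, read by CCK-8 assay, with a stated time of 72 h, tested at 8 uM; a lower number here means a weaker effect, a higher number a stronger effect of the compound at the concentration tested. Compound 1 `CC(C)n1cnc2c(Nc3cccc(Cl)c3)nc(NCOCc3ccc(C(=O)Nc4ccccc4N)cc3)nc21` gives 63.4%. Compound 2 `Nc1ccccc1NC(=O)c1ccc(CNc2nc(Cl)nc3c2ncn3Cc2ccccc2)cc1` gives 11.5%, and compound 3 `COC(CCn1cnc2c(NCc3ccc(C(=O)Nc4ccccc4N)cc3)nc(Cl)nc21)OC` gives 11.9%, so compound 3 stands second highest of the three numbers, close to compound 2 and far from compound 1. Among the compounds with values here, the one measured step that bears here is the change on the saturated chain carbon bound to the aromatic nitrogen, where 2,2-dimethoxyethyl replaced phenyl: a number 0.4 percentage points higher from compound 2 to compound 3 (within the scatter). Compound 4 `CCCCn1cnc2c(NCc3ccc(C(=O)Nc4ccccc4N)cc3)nc(Cl)nc21` has not yet been measured; it differs from compound 3 as ethyl in place of dimethoxymethyl on a saturated chain carbon, two bonds along the chain from an aromatic nitrogen. Since swapping the whole side group at that chain carbon left the number unchanged within the scatter, a smaller change within the same chain is expected to leave it unchanged as well, so the step of a number 0.1 percentage points higher from compound 3 to compound 4 (within the scatter) is expected to stay within the scatter. For compound 4 the estimate in this assay is 12%, with a range from 3% to 25%.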

Compound 4, a percentage reported as inhibition, at one concentration (the size of the read-out at that concentration, not a potency): 40.9%
Estimate against measurement, compound 4: 28.9 percentage points below; the whole stated range lies below it.
By their numbers in this assay, from the lowest: compounds 2 and 3 (each within the scatter of the next); then compound 4; then compound 1.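

In this assay, this position proves able to move the read-out after all: ethyl in place of dimethoxymethyl gives a number 29 percentage points higher from compound 3 to compound 4 (beyond the scatter), whereas the earlier swap had shown no change beyond the scatter. Propyl in place of phenyl, at the chain carbon bound to the aromatic nitrogen, gives a number 29.4 percentage points higher from compound 2 to compound 4 (beyond the scatter), so the unbranched butyl chain of compound 4 stands apart from both earlier side groups. Losing the two oxygens cannot be the whole story, since the phenyl of compound 2 carries no oxygen either and its number still lies within the scatter of that of compound 3.

No measurement here explains why the plain chain gives the higher number. Also open, as far as these compounds go, is how a longer chain, such as hexyl, or an amine or a carboxylic acid at the chain end would fare.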